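Second chloro on the core: expectation for compound 4

The source may report more compounds than this note shows. Statements on the series, on what has been measured and on what is new or still open speak of the compounds shown alone.

Measured compounds:
Compound 1, `ClCc1ccccc1Cn1cnc2c(Cl)ncnc21`: 3230 nM
Compound 2, `ClCc1cccc(Cn2cnc3ncnc(Cl)c32)c1`: 22400 nM
Compound 3, `ClCc1cccc(Cn2cnc3c(Cl)ncnc32)c1`: 3890 nM

In a functional assay on CCRF-CEM cells (Homo sapiens) for cytotoxicity, read by sulforhodamine B assay, with a stated time of 48 h (a higher number here means a weaker inhibitor of growth, a lower number a stronger inhibitor of growth), compound 3 gives 3890 nM, the second highest of the three numbers. Compound 1 sits closest, within the usual scatter, while compound 2 lies furthest away, beyond it. Compound 4, `ClCc1cccc(Cn2cnc3c(Cl)nc(Cl)nc32)c1`, has not yet been measured. It differs from compound 3 by chloro in place of hydrogen on an aromatic carbon, on an aromatic carbon between two ring nitrogen atoms of the shared core. Among the compounds with values here, no measured pair shows this change, so the step from compound 3 to compound 4 can only be guessed. The expected step of a 1.3-fold lower number from compound 3 to compound 4 (0.11 log units; within the scatter) is small, most likely no change beyond the scatter. Compound 4 is therefore estimated at 3000 nM, with a range from 800 nM to 12000 nM.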

Compound 4, concentration for total growth inhibition: > 100000 nM
Compound 4 was reported as a limit; the forecaster's own chance of this, stated with the estimate: 5%; middle value at least 33-fold (1.52 log units) away from the limit.
By their numbers in this assay, from the lowest: compounds 1 and 3 (each within the scatter of the next); then compound 2. At a limit, above all of these: compound 4.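

Within the data shown here, the aromatic carbon between two ring nitrogen atoms of the shared core carries hydrogen in all the earlier compounds, so they could not show how much this position matters. In this assay, chloro in place of hydrogen there gives an at least 25-fold higher number from compound 3 to compound 4 (1.41 log units; beyond the scatter), so one added heavy atom can weaken growth inhibition well beyond the scatter. Compound 4 has only a limit and not a number: the limit of > 100000 nM in this assay, at which 1 of the 4 values shown sits. The compounds shown leave open whether an amine or a methyl group at this position would keep the growth inhibition of compound 3.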